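Swapping a cyclohexyl for a hydroxylated chain

The source may report more compounds than this note shows. Statements on the series, on what has been measured and on what is new or still open speak of the compounds shown alone.

Measured so far in an assay on BaF3 cells for inhibition of proto-oncogene tyrosine-protein kinase receptor Ret variant V804M (Homo sapiens), read by MTT assay, with a stated time of 48 h; a higher number here means a weaker inhibitor of growth, a lower number a stronger inhibitor of growth:
- compound 1 `CC(C)n1nc(-c2cc(C(C)(C)C)on2)c2c(N)ncnc21` gives 7310 nM
- compound 2 `Nc1ncnc2c1c(-c1cc(C3CC3)on1)nn2C1CCCCC1` gives 2000 nM

Within the data shown here, compound 2 has the lowest of the two numbers; the only other value, that of compound 1, is higher, and that gap lies beyond the usual scatter. Compound 1 and compound 2 differ in two places at once, so nothing can be said about what either change alone contributes.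

Compound 3 `CC(C)(O)Cn1nc(-c2cc(C3CC3)on2)c2c(N)ncnc21` keeps the shared core of compound 2 and its 5-cyclopropyl-1,2-oxazol-3-yl group, and changes only the group on the aromatic nitrogen: 2-hydroxy-2-methylpropyl in place of cyclohexyl on an aromatic nitrogen. Among the measured compounds shown here, no measured pair shows this kind of exchange, so there is no step in hand to lean on. For the measured compounds named here, the change trades a ring for a short chain carrying a hydroxyl, a type of change for which the data offer no precedent; the most defensible expectation is a small step, if any, with a weaker result somewhat more likely than a stronger one.

Compound 3 is therefore estimated to give 3000 nM in this assay, within a range of 800 nM to 12000 nM, which would mean an expected step of a 1.5-fold higher number from compound 2 to compound 3 (0.18 log units; within the scatter).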

Compound 3, concentration for 50% growth inhibition: 6750 nM
Compound 3: middle estimate off by 2.3-fold (0.35 log units), on the low side; the measured number falls inside the stated range.
By their numbers in this assay, from the lowest: compound 2; then compounds 3 and 1 (each within the scatter of the next).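

In this assay, the step from cyclohexyl to 2-hydroxy-2-methylpropyl on the aromatic nitrogen gives a 3.4-fold higher number from compound 2 to compound 3 (0.53 log units; beyond the scatter). Among these compounds, this is the first exchange made in one place only, and it shows that the group on this nitrogen can shift the number on its own, in this case towards weaker inhibition of growth. The step cannot say why, however, since the ring leaves and the hydroxyl enters together, and nothing at hand explains the rise in the number.

The compounds shown leave open whether the loss of the ring or the arrival of the hydroxyl accounts for the step: a plain 2-methylpropyl chain would carry the same branched shape without the hydroxyl, while a hydroxycyclohexyl group would keep the ring and add the hydroxyl. Also open, as far as these compounds go, is whether a group such as a piperidine ring, which carries an amine, or a longer chain ending in a hydroxyl would move the number at this nitrogen in the same direction or the opposite one.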